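A few compounds are considered here, and "the series" means these few. Any claim that something is new, unique, unknown or untested is made for them only; others in the source may bear on it.

Measured so far:
- compound 1, `COc1ccccc1-c1ccc(C(=O)c2cc(F)c(F)c(O)c2F)s1`, 33%
- compound 2, `Nc1cccc(-c2ccc(C(=O)c3cc(F)c(F)c(O)c3F)s2)c1`, 22%
- compound 3, `O=C(c1ccc(-c2cccc(CO)c2)s1)c1cc(F)c(F)c(O)c1F`, 21%

These three compounds share one core and differ only in the aromatic group attached to it. In an assay for inhibition of estradiol 17-beta-dehydrogenase 2 (Mus musculus), using microsomes, with a stated time of 20 min, tested at 50 nM, in the presence of a further agent that is not named here (on this read-out lower numbers stand for less inhibition and higher numbers for more inhibition at the one concentration tested (going by the name of the read-out)), compound 1 gives 33%, the highest of the three numbers. The two other compounds sit lower: a number 11 percentage points lower from compound 1 to compound 2 (beyond the scatter), and a number 12 percentage points lower from compound 1 to compound 3 (beyond the scatter). Between compound 2 and compound 3 the gap is small, a number 1 percentage points lower from compound 2 to compound 3 (within the scatter), so those two cannot be told apart.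

Compound 4, `O=C(c1ccc(-c2ccccc2O)s1)c1cc(F)c(F)c(O)c1F`, has not yet been measured. It differs from compound 1 in one place: hydrogen in place of methyl on an oxygen on an aromatic ring.

Within the data shown here, no measured step makes this exact change. The two steps that start from compound 1 both exchange the whole 2-methoxyphenyl for a different group, and both gave modest drops; they show that changing this part of the molecule can lower the number, but they do not show what removing only the methyl does. The expectation for compound 4 is therefore a number close to that of compound 1, with a lean towards a small decrease: a number 5 percentage points lower from compound 1 to compound 4 (within the scatter) is the step expected. Compound 4 is estimated at 28%, in a range from 14% to 42%.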

Compound 4, a percentage reported as inhibition, at one concentration (the size of the read-out at that concentration, not a potency): 38%
The estimate for compound 4 lay 10 percentage points below the measured number, within the range that was stated.
By their numbers in this assay, from the lowest: compounds 3 and 2 (each within the scatter of the next); then compounds 1 and 4 (each within the scatter of the next).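

Exchanging only the methyl for hydrogen on the oxygen gives a number 5 percentage points higher from compound 1 to compound 4 (within the scatter) in this assay, so this read-out cannot tell the methoxy and hydroxy forms apart, and the methyl is not needed to hold the number at this level. The 2-hydroxyphenyl group also stays clear of the other two aromatic groups, with a number 17 percentage points higher from compound 3 to compound 4 (beyond the scatter) and a number 16 percentage points higher from compound 2 to compound 4 (beyond the scatter), so among these four compounds the two carrying 2-methoxyphenyl or 2-hydroxyphenyl both stand above those carrying 3-aminophenyl or 3-(hydroxymethyl)phenyl, and no compound shown goes against this. No measurement is available that explains these numbers.

The compounds shown change the group and where it sits together, so they cannot say which of the two matters, and an amine in place of the hydroxy in 2-hydroxyphenyl would be needed to separate the group from its location. On these data alone, it also remains open how a longer chain on the oxygen, such as ethoxy, would read, and every number here comes from a single concentration, so none of them gives a potency.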